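Swapping Chloro for Trifluoromethyl on the Urea Ring

The compounds below may be only part of what the source reports. "The series", "measured", "known", "first", "only" and "open" are said of these compounds alone.

Compound 1, `COc1cc(-c2nn(-c3cccc(NC(=O)Nc4ccc(Cl)c(Cl)c4)c3)cc2-c2ccncc2)ccc1Cl`, was tested in a functional assay on NCI-H522 cells (Homo sapiens) for inhibition, read by sulforhodamine B assay, with a stated time of 48 h (a higher number here means a weaker inhibitor of growth, a lower number a stronger inhibitor of growth), where compound 1 gives 811 nM. Among the three measured compounds this number stands second highest: compound 3, `O=C(Nc1cccc(-n2cc(-c3ccncc3)c(-c3ccc(Cl)c(O)c3)n2)c1)Nc1cc(C(F)(F)F)cc(C(F)(F)F)c1`, gives 724 nM, and compound 2, `O=C(Nc1cccc(-n2cc(-c3ccncc3)c(-c3ccc(Cl)c(O)c3)n2)c1)Nc1ccc(Cl)c(Cl)c1`, gives 1190 nM, and both of these lie within the scatter of the number for compound 1. Going by the values given here, the only measured step that changes a single group, a 1.5-fold higher number from compound 1 to compound 2 (0.17 log units; within the scatter), touches a different part of the molecule and so says little about the change considered here.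

Compound 4, `COc1cc(-c2nn(-c3cccc(NC(=O)Nc4ccc(Cl)c(C(F)(F)F)c4)c3)cc2-c2ccncc2)ccc1Cl`, differs from compound 1 in one place: trifluoromethyl in place of chloro on an aromatic carbon. Among the compounds with values here, no measured pair isolates this change. Compound 2 and compound 3 differ in the same part of the structure, though in more than one place, and their two values lie within the scatter of each other, which suggests that alterations in this region have so far shifted the number little. A small step is therefore expected, a 1.2-fold lower number from compound 1 to compound 4 (0.06 log units; within the scatter), with no clear direction. Compound 4 is estimated at 700 nM in this assay, with a likely range from 350 nM to 1500 nM.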

Compound 4, concentration for 50% growth inhibition: 1140 nM
Estimate against measurement, compound 4: 1.6-fold (0.21 log units) below; the measured number falls inside the stated range.
By their numbers in this assay, from the lowest: compounds 3, 1, 4 and 2 (each within the scatter of the next).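

The step from 3,4-dichlorophenyl to 4-chloro-3-(trifluoromethyl)phenyl, with everything else in the molecule held fixed, gives a 1.4-fold higher number from compound 1 to compound 4 (0.15 log units; within the scatter) in this assay. This pair isolates the change directly, where compound 2 and compound 3 differ in more than one place and could only hint at it. At this aromatic carbon, ortho to a chloro group, a trifluoromethyl group of 4 heavy atoms can stand in place of a chloro group of 1 heavy atom, and the two compounds cannot be told apart in this assay; nothing shown here offers an explanation for this result.

On these data alone, both groups at this carbon lack hydrogen-bond donors and acceptors, so it remains open whether a group of another kind there, such as an amine or a carboxylic acid, would leave the number just as undisturbed. As far as these compounds go, it is also open whether the same swap would read the same way on the core of compound 2, which has hydrogen in place of the methyl on the oxygen.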